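The compounds below may be only part of what the source reports. "The series", "measured", "known", "first", "only" and "open" are said of these compounds alone.

Measured so far:
- compound 1, `O=C(/C=C/c1coc2cc(O)ccc2c1=O)NCc1ccc(F)cc1`: > 100000 nM
- compound 2, `COc1ccc2c(=O)c(/C=C/C(=O)Nc3cccc(Cl)c3)coc2c1`: 11900 nM
- compound 3, `COc1ccc2c(=O)c(/C=C/C(=O)Nc3ccc(C)cc3)coc2c1`: 24100 nM

In a functional assay on HeLa cells (Homo sapiens) for inhibition, read by MTT assay, with a stated time of 48 h (on this read-out higher numbers stand for weaker inhibition and lower numbers for stronger inhibition), compound 1 gives > 100000 nM, which is a limit of the assay rather than a number (the limit of > 100000 nM in this assay, at which 1 of the 3 values shown sits). Compound 2 gives 11900 nM and compound 3 gives 24100 nM; compound 3 thus has the higher of the two numbers, and the step of a 2.0-fold higher number from compound 2 to compound 3 (0.31 log units; beyond the scatter) is a modest one beyond the scatter.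

The unmeasured compound 4, `COc1ccc2c(=O)c(/C=C/C(=O)NCc3cccc(F)c3)coc2c1`, differs from compound 3 in one place: 3-fluorobenzyl in place of 4-methylphenyl on an amide-type nitrogen. Going by the values given here, the only measured step, a 2.0-fold higher number from compound 2 to compound 3 (0.31 log units; beyond the scatter), exchanges one aromatic group for another directly on the amide nitrogen and says little about inserting a benzyl-type linker. Among the compounds with values here, compound 1 also carries a benzyl group on its amide nitrogen, but it differs from compound 4 in more than one place, so it offers no single step. The evidence therefore allows no confident direction.

Compound 4 is expected to give roughly 30000 nM, a step of a 1.2-fold higher number from compound 3 to compound 4 (0.10 log units; within the scatter) that is not expected to exceed the scatter, with a wide range from 8000 nM to 120000 nM.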

Compound 4, half-maximal inhibitory concentration: 17600 nM
Estimate against measurement, compound 4: 1.7-fold (0.23 log units) above; measured number inside the range.
By their numbers in this assay, from the lowest: compounds 2, 4 and 3 (each within the scatter of the next, the first and the last beyond it). At a limit, above all of these: compound 1.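

Going by these compounds alone, until now, the only change at this place exchanged one aromatic group for another on the amide-type nitrogen, and compound 4 shows that a benzyl-type group can stand there too. In this assay, 3-fluorobenzyl in place of 4-methylphenyl gives a 1.4-fold lower number from compound 3 to compound 4 (0.14 log units; within the scatter), and 3-fluorobenzyl in place of 3-chlorophenyl gives a 1.5-fold higher number from compound 2 to compound 4 (0.17 log units; within the scatter), so neither change moves the number beyond the scatter, and compound 4 cannot be ranked against either neighbour, even though compounds 2 and 3 lie just beyond the scatter of each other. Nothing known here explains why these numbers stay so close.

Open questions remain about the group itself: a plain benzyl, a benzyl with its fluorine elsewhere on the ring, or phenethyl with its longer chain might behave differently on the same core. As far as these compounds go, it also remains open whether a non-aromatic group on this nitrogen, such as cyclohexyl or an amine like morpholine, would hold the number in this range or move it clearly in either direction.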